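Series notes: methoxy for amino, compound 1 to compound 3

The compounds below may be only part of what the source reports. "The series", "measured", "known", "first", "only" and "open" are said of these compounds alone.

Measured so far:
compound 1 `COc1cc(-c2cc(/C=C/C(=O)c3ccc(N)cc3)[nH]n2)cc(OC)c1OC` — 5440 nM
compound 2 `COc1ccc(-c2cc(/C=C/C(=O)c3ccc(N)cc3)[nH]n2)cc1OC` — 15800 nM

In a functional assay on OVCAR-4 cells (Homo sapiens) for inhibition, read by sulforhodamine B assay, with a stated time of 48 h (on this read-out higher numbers stand for weaker inhibition of growth and lower numbers for stronger inhibition of growth), compound 1 gives the lowest of the two numbers; the nearest is compound 2, and the step of a 2.9-fold higher number from compound 1 to compound 2 (0.46 log units; beyond the scatter) arises from hydrogen in place of methoxy on an aromatic carbon.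

Compound 3 `COc1ccc(C(=O)/C=C/c2cc(-c3cc(OC)c(OC)c(OC)c3)n[nH]2)cc1` is not yet measured. It differs from compound 1 by methoxy in place of amino on an aromatic carbon, the change sitting para to a large group; cut one bond further out it reads 4-aminophenyl to 4-methoxyphenyl.

Going by the values given here, no measured step touches this exchange: the only step, between compound 1 and compound 2, concerns the other ring and gives no guide to this assay here. With nothing to rest on, no step beyond the scatter is expected in either direction, and the uncertainty is wide. Compound 3 is therefore expected to give 6000 nM, between 2000 nM and 20000 nM, an expected step of a 1.1-fold higher number from compound 1 to compound 3 (0.04 log units; within the scatter).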

Compound 3, concentration for total growth inhibition: 8320 nM
For compound 3 the middle estimate is 1.4-fold (0.14 log units) below the measured one; measured number inside the range.
By their numbers in this assay, from the lowest: compounds 1, 3 and 2 (each within the scatter of the next, the first and the last beyond it).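

In this assay the exchange of amino for methoxy, para to a large group, gives a 1.5-fold higher number from compound 1 to compound 3 (0.18 log units; within the scatter) and so stays within the scatter, even though the hydrogen-bond donor counted for amino does not enter with methoxy. Going by these compounds alone, on this single pair, the position accepts either group without a step that can be separated from the scatter, whereas the exchange on the other ring, a 2.9-fold higher number from compound 1 to compound 2 (0.46 log units; beyond the scatter), remains the only step here beyond it. No measurement at hand accounts for either result.

On these data alone, whether hydroxyl, dimethylamino or a bare hydrogen at this position would also stay within the scatter remains open. Also open, as far as these compounds go, is whether methoxy for amino reads the same on the ring carried by compound 2.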